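Benzyl to ethyl: what half-life to expect

The source may report more compounds than this note shows. Statements on the series, on what has been measured and on what is new or still open speak of the compounds shown alone.

In an ADME assay on the whole organism (plasma) for pharmacokinetics, with Homo sapiens as the target (a higher number here means that the compound lasts longer, a lower number that the compound disappears faster), compound 1 `CC[C@@H](C(=O)N[C@H](/C=C/C(=O)OCc1ccccc1)C[C@@H]1CCNC1=O)n1cccc(NC(=O)c2cc(C)on2)c1=O` gives 2.5 h. Compound 2 `C#CC[C@@H](C(=O)N[C@H](/C=C/C(=O)OCc1ccccc1)C[C@@H]1CCNC1=O)n1cccc(NC(=O)c2cc(C)on2)c1=O` gives 4.3 h, and compound 3 `C#CC[C@@H](C(=O)N[C@H](/C=C/C(=O)OC1CCC1)C[C@@H]1CCNC1=O)n1cccc(NC(=O)c2cc(C)on2)c1=O` gives 3.3 h. These three values all lie within the usual scatter of one another, so compound 1 cannot be clearly separated from either neighbour.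

Compound 4 `CCOC(=O)/C=C/[C@H](C[C@@H]1CCNC1=O)NC(=O)[C@H](CC)n1cccc(NC(=O)c2cc(C)on2)c1=O` is compound 1 with methyl in place of phenyl on a saturated chain carbon bound to an oxygen next to a carbonyl group. Cut one bond further out, this reads benzyl to ethyl.

The closest measured change alters the same benzyl group, with cyclobutyl in place of benzyl on an oxygen next to a carbonyl group: a 1.3-fold lower number from compound 2 to compound 3 (0.11 log units; within the scatter). That change was made on compound 2, not on compound 1, so it is only a guide. The other measured change, ethynyl in place of methyl, lies elsewhere in the molecule: a 1.7-fold higher number from compound 1 to compound 2 (0.24 log units; within the scatter). It shows only how far values have moved in this small set. Among the compounds with values here, no ethyl compound has been measured yet, and neither step leaves the scatter, so no real shift is expected in this assay.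

The expected step is a 1.1-fold lower number from compound 1 to compound 4 (0.06 log units; within the scatter), which would stay within the scatter. For compound 4 the estimated value is 2.2 h, with an expected range from 1.2 h to 4 h.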

Compound 4, half-life in the Homo sapiens assay: 5.6 h
Beside the measured number, compound 4's estimate is 2.5-fold (0.41 log units) below it; measured number outside the range, above it.
By their numbers in the Homo sapiens assay, from the lowest: compounds 1, 3, 2 and 4 (each within the scatter of the next, the first and the last beyond it).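

Within the data shown here, in the Homo sapiens assay, compound 1 gives 2.5 h and compound 4 gives 5.6 h: the change from benzyl to ethyl gives a clear though modest step (a 2.2-fold higher number from compound 1 to compound 4 (0.35 log units; beyond the scatter)), the only step in this set that lies beyond the scatter. This shows that the group on this oxygen can shift the half-life, which the earlier step from benzyl to cyclobutyl (a 1.3-fold lower number from compound 2 to compound 3 (0.11 log units; within the scatter)) did not show. In a physicochemical assay for solubility, measured as thermodynamic solubility (a lower number here means a less soluble compound, a higher number a more soluble compound), compound 1 gives 41 ug/mL and compound 4 gives 38 ug/mL, and the same change from benzyl to ethyl stays within the scatter (a 1.1-fold lower number from compound 1 to compound 4 (0.03 log units; within the scatter)). Nothing available here explains the longer half-life of the ethyl compound.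

The compounds shown leave open whether benzyl to ethyl would give a step of this size on compound 2, which carries the ethynyl group, or whether the step belongs to the core of compound 1 alone. They also leave open how the half-life responds to other groups at this place, such as a longer chain like butyl or a chain ending in an amine, and whether the solubility would again stay within the scatter.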